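The source may report more compounds than this note shows. Statements on the series, on what has been measured and on what is new or still open speak of the compounds shown alone.

Notes on the series. The shared core is carried by compound 1 `CC(=O)N[C@@H]1CCC[C@H](C(=O)Nc2cc(-c3cnn4c3CCCC4)ccn2)C1`, compound 2 `CC(=O)N[C@@H]1CCC[C@H](C(=O)Nc2cc(-c3cnn4c3CCCC4)c(F)cn2)C1`, compound 3 `CC(=O)N[C@@H]1CCC[C@H](C(=O)Nc2cc(-c3cnn4c3CCCC4)c(Cl)cn2)C1` and compound 4 `CC(=O)N[C@@H]1CCC[C@H](C(=O)Nc2cc(-c3cnc4n3CCCC4)c(Cl)cn2)C1`. In an ADME assay on cells (Hepatocyte, Rattus norvegicus) for metabolic stability, using equilibrium dialysis (a lower number here means slower removal, a higher number faster removal of the compound), compound 1 gives 33 uL/min, compound 2 gives 73 uL/min, and compound 3 gives 46 uL/min. Among the three numbers compound 3 stands second highest; its nearest neighbour on the numbers is given by a 1.4-fold higher number from compound 1 to compound 3 (0.14 log units; within the scatter) and its furthest by a 1.6-fold lower number from compound 2 to compound 3 (0.20 log units; within the scatter). Within the data shown here, the only step beyond the scatter, a 2.2-fold higher number from compound 1 to compound 2 (0.34 log units; beyond the scatter), concerns fluoro in place of hydrogen on an aromatic carbon.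

Compound 4 has not yet been measured in this assay. It differs from compound 3 by a group of 9 heavy atoms (7 carbon, 2 nitrogen; one five-membered aromatic ring with 2 hetero atoms, one six-membered non-aromatic ring with 1 hetero atom) in place of a group of 9 heavy atoms (7 carbon, 2 nitrogen; one five-membered aromatic ring with 2 hetero atoms, one six-membered non-aromatic ring with 1 hetero atom), on an aromatic carbon; the two have the same atoms, joined differently. Among the measured compounds shown here, none of the measured steps touches this group: all three concern the halogen on the six-membered aromatic ring, and two of them stay within the scatter. For the measured compounds named here, no measured step bears on the change, so the expectation rests on compound 3 alone and on the narrow spread of the three numbers. The step of no change at the digits printed from compound 3 to compound 4 (within the scatter) is expected to stay within the scatter, in no particular direction. For compound 4 the estimate in this assay is 46 uL/min, with a range from 22 uL/min to 95 uL/min.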

Compound 4, intrinsic clearance in a liver preparation (reported as CLH), per the amount of preparation that the assay uses: 12 uL/min
Beside the measured number, compound 4's estimate is 3.8-fold (0.58 log units) above it; the measured number lies below the stated range.
By their numbers in this assay, from the lowest: compound 4; then compounds 1, 3 and 2 (each within the scatter of the next, the first and the last beyond it).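

Unlike the halogen steps, which left the group on the aromatic carbon ortho to the chloro group unchanged, this result shows that this assay also responds to the group at this position, opposite the ring nitrogen: a 3.8-fold lower number from compound 3 to compound 4 (0.58 log units; beyond the scatter), which is larger than the only earlier step beyond the scatter, a 2.2-fold higher number from compound 1 to compound 2 (0.34 log units; beyond the scatter). The two groups have the same atoms joined differently, and they match in heavy atoms, ring types, hydrogen-bond donors and acceptors, and net charge, so none of these counts separates them and the difference lies in how the atoms are joined. No supporting measurement is available to account for the step.

Going by these compounds, it remains open whether the rearranged group gives a step of similar size with fluoro or hydrogen in place of the chloro group, since this step has been read only with the chloro group present. Also open, on these data alone, is how a simpler ring at this position, such as a pyridine or a phenyl, would compare with the two groups here.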